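Thiocarbonyl substituent change from compound 3 to compound 4

The source may hold more compounds than are shown below. What is called first, only, known or untested is meant among the compounds shown, and "the series" means these compounds.

In a functional assay on HT-29 cells (Homo sapiens) for antiproliferative activity, read by MTT assay, with a stated time of 96 h (on this read-out higher numbers stand for weaker inhibition and lower numbers for stronger inhibition), three compounds on the shared core differ in the group on the thiocarbonyl carbon. Compound 1 `CSC(=S)N/N=C1\CC2(CCCCC2)Oc2c1ccc1ccccc21` gives 4130 nM, compound 2 `S=C(CN1CCCCC1)N/N=C1\CC2(CCCCC2)Oc2c1ccc1ccccc21` gives 8170 nM and compound 3 `NCCCCCCC(=S)N/N=C1\CC2(CCCCC2)Oc2c1ccc1ccccc21` gives 3870 nM. The standing of compound 3 rests on two steps: a 1.1-fold lower number from compound 1 to compound 3 (0.03 log units; within the scatter), and a 2.1-fold lower number from compound 2 to compound 3 (0.32 log units; beyond the scatter).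

Compound 4 `S=C(N/N=C1\CC2(CCCCC2)Oc2c1ccc1ccccc21)NC1CCCCC1` has cyclohexylamino in place of 6-aminohexyl on a thiocarbonyl carbon. Among the measured compounds shown here, no measured compound carries cyclohexylamino, so the evidence is indirect. The three measured changes at this part of the structure are all small: a 2.0-fold higher number from compound 1 to compound 2 (0.30 log units; within the scatter) is the remaining step, and the step to compound 3 from compound 2 above is the only one beyond the scatter, and only modestly. A step beyond the scatter is therefore not expected in this assay. The expected step is a 1.2-fold higher number from compound 3 to compound 4 (0.07 log units; within the scatter). For compound 4 the estimate is 4500 nM, with an expected range of 1800 nM to 11000 nM.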

Compound 4, half-maximal inhibitory concentration: 7440 nM
Beside the measured number, compound 4's estimate is 1.7-fold (0.22 log units) below it; the range from low to high includes it.
By their numbers in this assay, from the lowest: compounds 3, 1, 4 and 2 (each within the scatter of the next, the first and the last beyond it).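

In this assay, cyclohexylamino on a thiocarbonyl carbon gives no step beyond the scatter from any of the three earlier groups: a 1.9-fold higher number from compound 3 to compound 4 (0.28 log units; within the scatter), a 1.8-fold higher number from compound 1 to compound 4 (0.26 log units; within the scatter) and a 1.1-fold lower number from compound 2 to compound 4 (0.04 log units; within the scatter). The swap from 6-aminohexyl keeps the same heavy atoms, carbon and nitrogen alike, while bringing in a six-membered non-aromatic ring of carbon only, so an open chain and a carbocycle at this place remain inseparable on this read-out. No available measurement accounts for these numbers.

Still open, on these data alone, is whether a phenylamino group, a carboxylic acid or a shorter aminoalkyl chain on the thiocarbonyl carbon would give a larger step. The compounds shown also leave open whether the small spread holds for a change elsewhere on the shared core.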